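Same atoms, same bonds: a configuration left undrawn

The source may report more compounds than this note shows. Statements on the series, on what has been measured and on what is new or still open speak of the compounds shown alone.

Compound 3 `C[C@H](O)CCn1nc2c(Br)c(Br)c(Br)c(Br)c2n1` gives 100% in a functional assay on MCF7 cells (Homo sapiens) for antiproliferative activity, read by MTT assay, with a stated time of 48 h, tested at 12.5 uM (on this read-out lower numbers stand for a stronger effect and higher numbers for a weaker effect at the one concentration tested), with compound 1 `OC(CCn1nc2c(Br)c(Br)c(Br)c(Br)c2n1)c1cccc(Br)c1` at 102% and compound 2 `OC(CCn1nc2c(Br)c(Br)c(Br)c(Br)c2n1)c1ccc(F)cc1` at 109%, all three within the scatter of one another. Going by the values given here, the only step between measured compounds, a number 7 percentage points higher from compound 1 to compound 2 (within the scatter), moves nothing beyond the scatter either. Compound 4 `CC(O)CCn1nc2c(Br)c(Br)c(Br)c(Br)c2n1` differs from compound 3 as counted: the two compounds have the same atoms and bonds; at least one stereo element is drawn with a configuration in one of them and without one in the other: 1 of 1 stereo elements differ; a stereocentre at a saturated chain carbon is drawn S in compound 3 and without a configuration in compound 4. Among the compounds with values here, no measured step touches a drawn configuration, and the one step available changed nothing beyond the scatter, so for compound 4 the expected step is no change at the digits printed from compound 3 to compound 4 (within the scatter), nothing beyond the scatter. Compound 4 is therefore estimated at 100% in this assay, between 90% and 110%.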

Compound 4, a percentage reported as activity, at one concentration (the size of the read-out at that concentration, not a potency): 79%
Estimate against measurement, compound 4: 21 percentage points above, and the stated range ends above it.
By their numbers in this assay, from the lowest: compound 4; then compounds 3, 1 and 2 (each within the scatter of the next).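

In this assay this position shows its first change beyond the scatter, with no atom or bond altered: a number 21 percentage points lower from compound 3 to compound 4 (beyond the scatter). The only feature separating these two compounds is how the stereocentre is drawn: the fact that one of compounds 3 and 4 is drawn with a defined configuration and the other without, at the place where they differ. With no configuration drawn in compounds 1, 2 and 4, methyl in place of 3-bromophenyl gives a number 23 percentage points lower from compound 1 to compound 4 (beyond the scatter), and methyl in place of 4-fluorophenyl gives a number 30 percentage points lower from compound 2 to compound 4 (beyond the scatter).

The compounds shown leave open how a form drawn with the opposite configuration would read. They also leave open how an amine or a longer chain would read in place of the methyl.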